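Swapping Fluoro for Bromo on Compound 2

The source may report more compounds than this note shows. Statements on the series, on what has been measured and on what is new or still open speak of the compounds shown alone.

In a functional assay on MCF7 cells (Homo sapiens) for antiproliferative activity, read by MTT assay, with a stated time of 72 h (a higher number here means a weaker inhibitor, a lower number a stronger inhibitor), compound 1 `O=[N+]([O-])c1ccc(-c2csc(N3N=C(c4ccc(N5CCCCC5)cc4)CC3c3ccc(Cl)cc3)n2)cc1` reads > 100000 nM, which is a limit of the assay and not a number. Among the compounds with values here, compound 2 `Fc1ccc(-c2csc(N3N=C(c4ccc(N5CCCCC5)cc4)CC3c3ccc(Cl)cc3)n2)cc1` gives 23100 nM, the only exact number so far. Compound 3 `Clc1ccc(C2CC(c3ccc(N4CCCCC4)cc3)=NN2c2nc(-c3ccc(Br)cc3)cs2)cc1` carries bromo in place of fluoro on an aromatic carbon. Within the data shown here, the one measured step, an at least 4.3-fold lower number from compound 1 to compound 2 (0.63 log units; beyond the scatter), changed the group at this same place, but it involved nitro, so it offers only loose guidance. The expected change, a 1.2-fold lower number from compound 2 to compound 3 (0.06 log units; within the scatter), stays within the scatter, with no clear direction. Compound 3 is estimated at 20000 nM, with an expected range of 7000 nM to 60000 nM.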

Compound 3, half-maximal inhibitory concentration: > 100000 nM
Compound 3: a limit, no number; the forecaster's own chance of this, stated with the estimate: 10%; at least 5.0-fold (0.69 log units) between middle value and limit.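

Fluoro to bromo at this place on the aromatic ring gives an at least 4.3-fold higher number from compound 2 to compound 3 (0.63 log units; beyond the scatter) in this assay, so exchanging one halogen atom for another is not a neutral change here. Of the three groups shown at this place, only fluoro now gives an exact number. The step from compound 1 to compound 3 cannot be read, because both values are limits: the limit of > 100000 nM in this assay, at which 2 of the 3 values shown sit.

On these data alone, whether a methoxy group or an amine would give an exact number at this place remains open. Chloro at this place is also open, and the limit for compound 3 leaves the full size of its step from compound 2 unknown.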